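The compounds below may be only part of what the source reports. "The series", "measured", "known", "first", "only" and "open" are said of these compounds alone.

Of the compounds shown here, two built on a shared core have been measured so far, compound 1 (`COc1ccc(-c2cc(=O)c3ccc(OCCCN4CCC(C)CC4)cc3o2)cc1`) and compound 2 (`COc1ccc(-c2cc(=O)c3ccc(OCCCCCCN4CCC(CCO)CC4)cc3o2)cc1`). In a functional assay, read by spectrophotometry (a lower number here means that less compound is needed, a higher number that more compound is needed for the effect), compound 1 gives 26.6 nM and compound 2 gives 34.4 nM, so compound 2 stands within the scatter of compound 1. Still unmeasured is compound 3 (`COc1ccc(-c2cc(=O)c3ccc(OCCCCCCCN4CCC(C)CC4)cc3o2)cc1`), which differs from compound 2 as follows: (4-methylpiperidin-1-yl)methyl in place of 4-(2-hydroxyethyl)piperidin-1-yl on a saturated chain carbon, six bonds along the chain from an oxygen on an aromatic ring. Thus (4-methylpiperidin-1-yl)methyl takes the place of 4-(2-hydroxyethyl)piperidin-1-yl on a saturated chain carbon, six bonds along the chain from an oxygen on an aromatic ring. Within the data shown here, no measured pair shows what such a change does. Among the measured compounds shown here, with only two values so close together, no step beyond the scatter is expected in this assay. The estimated value for compound 3 is 28 nM, with an expected range from 9 nM to 85 nM. The expected change is a 1.2-fold lower number from compound 2 to compound 3 (0.09 log units; within the scatter).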

Compound 3, half-maximal effective concentration: 42.6 nM
Compound 3: the middle estimate sits 1.5-fold (0.18 log units) below what was measured, within the range that was stated.
By their numbers in this assay, from the lowest: compounds 1, 2 and 3 (each within the scatter of the next).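

In this assay, (4-methylpiperidin-1-yl)methyl in place of 4-(2-hydroxyethyl)piperidin-1-yl on a saturated chain carbon, six bonds along the chain from an oxygen on an aromatic ring, gives a 1.2-fold higher number from compound 2 to compound 3 (0.09 log units; within the scatter) and so removes the hydrogen-bond donor of the leaving group without a step beyond the scatter. With the 4-methylpiperidine kept, 4-(4-methylpiperidin-1-yl)butyl in place of 4-methylpiperidin-1-yl, three bonds along the chain from an oxygen on an aromatic ring, gives a 1.6-fold higher number from compound 1 to compound 3 (0.20 log units; within the scatter) and thus also stays within the scatter. Nothing available accounts for either step.

The step from compound 2 to compound 3 alters the chain and the group on the piperidine together, so neither can be read alone. Open too, from the compounds shown here alone, is whether a carboxylic acid or a primary amine on the piperidine, or a still longer chain, would go beyond the scatter.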